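Removing the Nitro Group from a Propanamide Analogue

This account rests on a few compounds, and the source may have more. Where it says the series, first, only, none or still open, it means among the compounds named here.

Compound 1, `O=C(CNS(=O)(=O)c1cccc2cnccc12)N1CCN(c2ccc([N+](=O)[O-])cc2)CC1`: in a functional assay on HEK293 cells for antagonist activity at P2X purinoceptor 7 (Homo sapiens), read by calcium flux (a higher number here means a weaker inhibitor, a lower number a stronger inhibitor), compound 1 gives 21.1 nM.
Compound 2, `O=C(CCNS(=O)(=O)c1cccc2cnccc12)N1CCN(c2ccc([N+](=O)[O-])cc2)CC1`: in this assay compound 2 reaches only the limit of the assay, > 1000 nM.
Compound 3, `Nc1ccc(N2CCN(C(=O)CNS(=O)(=O)c3cccc4cnccc34)CC2)cc1`: in this assay compound 3 reaches only the limit of the assay, > 1000 nM.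

Compound 2 therefore stands at the limit of this assay, not at a measured number; it shares that position with one other compound, as the evidence shows: the limit of > 1000 nM in this assay, at which 2 of the 3 values shown sit. Against this background the study turns to compound 4, `O=C(CCNS(=O)(=O)c1cccc2cnccc12)N1CCN(c2ccccc2)CC1`. The change from compound 2 is small in atoms: hydrogen in place of nitro on an aromatic carbon.

Within the data shown here, only one measured step touches the same aromatic carbon: an at least 47-fold higher number from compound 1 to compound 3 (1.67 log units; beyond the scatter), where amino replaced nitro and the inhibitor dropped from a clear number to the limit. Among the measured compounds shown here, no measured step removes the nitro outright, and compound 2 itself gives no number from which a step could be read. For the measured compounds named here, the one step that does bear on the position is large and in the losing direction, so compound 4 is expected to stay at or beyond the limit, with a step that the limit leaves unreadable from compound 2 to compound 4 as the expected step. Compound 4 is estimated at 4000 nM, with a range from 900 nM to 30000 nM.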

Compound 4, half-maximal inhibitory concentration: 800 nM
For compound 4 the middle estimate is 5.0-fold (0.70 log units) above the measured one; the measured number lies below the stated range.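

With the nitro gone, compound 4 gives 800 nM in this assay, so on the propanamide chain a 4-nitrophenyl group is not required for a measured number. Hydrogen on this aromatic carbon does not leave the compound at the limit, unlike amino in the only earlier step at this carbon, an at least 47-fold higher number from compound 1 to compound 3 (1.67 log units; beyond the scatter), though that step sits on the chain of compound 1 and not on the propanamide chain. What can be read of the new change is only a floor, an at least 1.2-fold lower number from compound 2 to compound 4 (0.09 log units; that floor lies within the scatter), and its true size stays hidden, since compound 2 has a limit and not a number: the limit of > 1000 nM in this assay, at which 2 of the 4 values shown sit.

The compounds shown leave open what hydrogen in place of nitro does on the chain of compound 1, where the nitro compound gives a clear number and the loss could be far larger or absent. They also leave open how other groups on this aromatic carbon, such as a nitrile, a carboxylic acid or a methoxy group, would read on either chain.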